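The compounds below may be only part of what the source reports. "The series", "measured", "known", "first", "only" and "open" are said of these compounds alone.

Measured so far:
compound 1 `Fc1ccc(Oc2ncnc3[nH]ccc23)c(F)c1`: 710 nM
compound 2 `Fc1ccc(Oc2ncnc3[nH]ccc23)cc1F`: 3000 nM
compound 3 `Fc1ccccc1Oc1ncnc2[nH]ccc12`: > 32000 nM (a limit, not a number)

All three were run in an assay on HEK293-TREx cells for antagonist activity at transient receptor potential cation channel subfamily A member 1 (Homo sapiens), read by fluorescence and calcium flux, with a stated time of 72 h; on this read-out higher numbers stand for weaker inhibition and lower numbers for stronger inhibition. Compound 3 sits at the limit of > 32000 nM in this assay, at which 1 of the 3 values shown sits. Compound 1 and compound 2 hold the same atoms joined differently; the difference between the two cores is not broken down here. From compound 1 to compound 3 the change is hydrogen in place of fluoro on an aromatic carbon, and it gave an at least 45-fold higher number from compound 1 to compound 3 (1.65 log units; beyond the scatter).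

Compound 4 `Fc1cccc(Oc2ncnc3[nH]ccc23)c1` is not yet measured; from compound 2 it differs by hydrogen in place of fluoro on an aromatic carbon. This is the same kind of change as from compound 1 to compound 3, though the surroundings differ: meta to a fluoro group in the first case, ortho to a fluoro group in the second. The expected step is a 10-fold higher number from compound 2 to compound 4 (1.00 log units; beyond the scatter), resting on an at least 45-fold higher number from compound 1 to compound 3 (1.65 log units; beyond the scatter) and on compound 2 starting from 3000 nM. Compound 4 is therefore expected to give 30000 nM, between 8000 nM and 100000 nM, with a real chance that only a limit is reported.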

Compound 4, half-maximal inhibitory concentration: > 32000 nM
Compound 4 was reported as a limit (the forecaster's own chance of this, stated with the estimate: 60%); middle value at least 1.0-fold (0.02 log units) from the limit.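

In this assay, hydrogen in place of fluoro on an aromatic carbon gave an at least 10-fold higher number from compound 2 to compound 4 (1.02 log units; beyond the scatter). The change therefore raises the number on both cores, but its size cannot be compared between them: the same change on two cores in this assay, an at least 45-fold higher number (1.65 log units; beyond the scatter) from compound 1 to compound 3 and an at least 10-fold higher number (1.02 log units; beyond the scatter) from compound 2 to compound 4; the limit leaves it open whether they differ

Neither compound 3 nor compound 4 gives a true number, as each value is a limit, so the full size of both steps stays unknown: the limit of > 32000 nM in this assay, at which 2 of the 4 values shown sit.

Open, from the compounds shown here alone, is whether another group in place of the fluoro, such as chloro, methoxy or a nitrile, would keep inhibition on either core. Also open, going by these compounds, is how far compound 3 and compound 4 lie beyond the limit.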